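Cyclohexanone sulfonamides: aryl substituent and HL-60 inhibition

The source may hold more compounds than are shown below. What is called first, only, known or untested is meant among the compounds shown, and "the series" means these compounds.

Two anilides share the oxocyclohexane sulfonamide core. Compound 1 `Cc1ccc(NS(=O)(=O)C2CCCCC2=O)c(C)c1` gives 12.2% in a functional assay on HL-60 cells (Homo sapiens) for antiproliferative activity, read by MTT assay, tested at 100 ug/mL; a lower number here means less inhibition, a higher number more inhibition at the concentration tested (going by the name of the read-out). Compound 2 `O=C1CCCCC1S(=O)(=O)Nc1ccc(Cl)cc1` gives -13% in this assay, the lower of the two numbers measured, with compound 1 standing higher by a margin beyond the scatter. Compound 3 `Cc1ccc(NS(=O)(=O)C2CCCCC2=O)cc1` has not yet been measured; it differs from compound 2 by methyl in place of chloro on an aromatic carbon. As compound 1, which also carries methyl groups, sits higher than compound 2, a modest upward step is expected rather than none, a number 17 percentage points higher from compound 2 to compound 3 (beyond the scatter). Compound 3 is estimated at 4%, within -12% to 20%.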

Compound 3, a percentage reported as inhibition, at one concentration (the size of the read-out at that concentration, not a potency): -3.55%
The estimate for compound 3 lay 7.6 percentage points above the measured number, and the stated range covers the measured number.
By their numbers in this assay, from the lowest: compounds 2 and 3 (each within the scatter of the next); then compound 1.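

Methyl in place of chloro on an aromatic carbon para to a large group gives a number 9.5 percentage points higher from compound 2 to compound 3 (within the scatter) in this assay, so this change alone does not separate the two compounds. Hydrogen in place of methyl on an aromatic carbon gives a number 15.8 percentage points lower from compound 1 to compound 3 (beyond the scatter), which places the only step beyond the scatter at the extra methyl of compound 1. Nothing available explains either step.

As far as these compounds go, whether an amine or a methoxy group para to a large group would move the number beyond the scatter remains open. Also open, from the compounds shown here alone, is whether a chloro in place of the extra methyl of compound 1 would keep that step.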